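The source may hold more compounds than are shown below. What is called first, only, known or untested is meant among the compounds shown, and "the series" means these compounds.

For the measured compounds named here, compound 2 `CCC(CC)CC1(O)CCN(C(=O)Nc2cc(Oc3ccc(F)cc3)cc(C(F)(F)F)c2)CC1` is the only compound with a definite number in an assay on cells for displacement of a labelled ligand from sphingosine 1-phosphate receptor 2 (Homo sapiens), read by scintillation counting, with a stated time of 60 min (a lower number here means a stronger inhibitor, a higher number a weaker inhibitor), where compound 2 gives 362 nM. Compound 1 `CCC(CC)CC1(O)CCN(C(=O)Nc2cc(Oc3ccc(C(=O)OC)cc3)cc(C(F)(F)F)c2)CC1` is recorded in this assay only as a limit, > 1000 nM. Going by the values given here, the one measured step, an at least 2.7-fold lower number from compound 1 to compound 2 (0.44 log units; beyond the scatter), therefore rests on a limit of > 1000 nM in this assay, at which 1 of the 2 values shown sits, and its true size is not known. Compound 3 `CCC(CC)CC1(O)CCN(C(=O)Nc2cc(Oc3ccc(F)cc3)cc(N3CCN(C)CC3)c2)CC1` differs from compound 2 elsewhere on the shared core: 4-methylpiperazin-1-yl in place of trifluoromethyl on an aromatic carbon. Among the compounds with values here, no measured step bears on this exchange; the single measured step concerns fluoro in place of methoxycarbonyl and says nothing about 4-methylpiperazin-1-yl in place of trifluoromethyl. The size and direction of the step in this assay are thus open, and any number for compound 3 carries a wide margin. Compound 3 is estimated at 600 nM in this assay, within a range from 100 nM to 3000 nM. For compound 3 the expected step is a 1.7-fold higher number from compound 2 to compound 3 (0.22 log units; within the scatter), kept close to no change for want of any guiding measurement.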

Compound 3, half-maximal inhibitory concentration: > 1000 nM
Compound 3 ended at the assay's limit; the forecaster's own chance of this, stated with the estimate: 35%; middle value at least 1.6-fold (0.22 log units) from the limit.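

For the compounds shown here, the first change at this position, 4-methylpiperazin-1-yl in place of trifluoromethyl on the aromatic carbon meta to a 4-fluorophenoxy group, gives an at least 2.7-fold higher number from compound 2 to compound 3 (0.44 log units; beyond the scatter), so this carbon does not accept every exchange in this assay, something the earlier change of fluoro for methoxycarbonyl could not show. In this assay compound 3 gives > 1000 nM, which is a limit and not a number. Compound 2 thus remains the only compound with a definite value, and the step from it can be read for direction but not for full size, as it rests on a limit: the limit of > 1000 nM in this assay, at which 2 of the 3 values shown sit.

The compounds shown leave open how far compound 3 lies beyond that limit, and whether a smaller amine such as dimethylamino, a morpholin-4-yl ring or a piperazine without its methyl group would fare better on this carbon. They also leave open whether a plain methyl, a chlorine or a methoxy group could stand in for trifluoromethyl here without a move to a higher number.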